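Opening the Cyclopropane Ring: What to Expect for Compound 3

This account rests on a few compounds, and the source may have more. Where it says the series, first, only, none or still open, it means among the compounds named here.

In a functional assay on CHO cells for agonist activity at Free fatty acid receptor 1 (Homo sapiens), read by reporter gene assay (on this read-out lower numbers stand for smaller maximal responses and higher numbers for larger maximal responses), compound 1 `O=C(O)CCc1ccc(NCc2ccc(-c3ccccc3)cc2)cc1` gives 111%, and compound 2 `O=C(O)C1CC1c1ccc(NCc2ccc(-c3ccccc3)cc2)cc1` gives 80%. For the measured compounds named here, compound 2 therefore stands lowest of the two numbers recorded so far, and the only measured step, a number 31 percentage points lower from compound 1 to compound 2 (beyond the scatter), lies beyond the scatter. Compound 3 `O=C(O)CCCc1ccc(NCc2ccc(-c3ccccc3)cc2)cc1` is not yet measured and differs from compound 2 in a single place: 3-carboxypropyl in place of 2-carboxycyclopropyl on an aromatic carbon. The step from compound 1 to compound 2 is the one that bears on this change, since it, too, exchanges an open chain for the 2-carboxycyclopropyl group, only in the other direction; it was large. Going by the values given here, compound 3 is therefore expected to move back toward compound 1, with the caveat that no measured compound carries a 3-carboxypropyl group, so the estimated step is a number 20 percentage points higher from compound 2 to compound 3 (beyond the scatter). On this basis compound 3 is estimated at 100%, within a range from 78% to 122%.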

Compound 3, largest response reached (reported as percent of maximum), in percent of the reference or control that the assay uses: 62%
Compound 3: middle estimate off by 38 percentage points, on the high side; measured number below the stated range.
By their numbers in this assay, from the lowest: compound 3; then compound 2; then compound 1.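

Opening the ring did not bring the response back in this assay: the step of a number 18 percentage points lower from compound 2 to compound 3 (beyond the scatter) runs downward, so the 3-carboxypropyl group, with the same number of heavy atoms as 2-carboxycyclopropyl, gives the lowest response of the three. Within the open chains, the change a number 49 percentage points lower from compound 1 to compound 3 (beyond the scatter) is the larger of the two new steps, which shows that this position responds strongly to chain length and that an open chain alone does not secure a high maximal response. No measurement offered here accounts for either step.

From the compounds shown here alone, what remains open is whether a longer chain such as 4-carboxybutyl would continue this decline, or whether a shorter carboxymethyl group would also lose response. Also open, going by these compounds, is how a tetrazole in place of the carboxylic acid would behave on the 2-carboxyethyl chain.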